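The source may hold more compounds than are shown below. What is called first, only, known or untested is meant among the compounds shown, and "the series" means these compounds.

Measured so far:
Compound 1, `COc1ccc(NC(=O)NC2CC(C)(C)Oc3ccc(Br)cc32)cc1`: in a functional assay (aorta) with Rattus norvegicus as the target (a higher number here means that more compound is needed for the effect, a lower number that less compound is needed), compound 1 gives > 10000 nM.
Compound 2, `Cc1ccccc1NC(=O)NC1CC(C)(C)Oc2ccc(Cl)cc21`: in this assay compound 2 gives > 10000 nM.

Among the measured compounds shown here, both readings are limits of the assay rather than numbers, so no step between compound 1 and compound 2 can be computed. For the measured compounds named here, compound 2 therefore stands only at a limit, and the one further value shown, that of compound 1, is a limit as well (the limit of > 10000 nM in this assay, at which 2 of the 2 values shown sit).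

Compound 3, `Cc1ccccc1NC(=O)NC1CC(C)(C)Oc2ccc(Br)cc21`, differs from compound 2 in a single place: bromo in place of chloro on an aromatic carbon, in words, bromo in place of chloro on an aromatic carbon. Going by the values given here, no measured step covers this change, so the expectation rests on where compound 2 stands. The expected step that the limit leaves unreadable from compound 2 to compound 3 is none beyond the scatter. Compound 3 is thus estimated to sit at about 15000 nM, within a range from 5000 nM to 50000 nM, most likely again reported only as a limit.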

Compound 3, half-maximal effective concentration: > 30000 nM
Compound 3: no number, only a limit; the forecaster's own chance of this, stated with the estimate: 80%; middle value at least 2.0-fold (0.30 log units) away from the limit.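

Compound 3 gives > 30000 nM in this assay, which is a limit and not a number. Among the compounds shown here, compound 1 and compound 2 also stand only at limits, so no step to compound 3 can be read. From the compounds shown here alone, how much of any of these three compounds the effect requires, and whether bromo in place of chloro changes that amount, stays open.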